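The source may report more compounds than this note shows. Statements on the series, on what has been measured and on what is new or still open speak of the compounds shown alone.

Compound 2 `CC(=O)OC[C@@H](OCc1ccccc1)[C@H]1OC(=O)C=C[C@H]1OCc1ccccc1` carries an acetyl on an oxygen on a saturated carbon, and in a functional assay on Jurkat cells (Homo sapiens) for antiproliferative activity, read by MTT assay, with a stated time of 6 days (a lower number here means a stronger inhibitor, a higher number a weaker inhibitor), compound 2 gives 14700 nM. Going by the values given here, of the two numbers measured so far this is the highest, and the nearest is compound 1 `COc1ccc(/C=C/C(=O)OC[C@@H](OCc2ccccc2)[C@H]2OC(=O)C=C[C@H]2OCc2ccccc2)cc1`, which in this assay gives 10300 nM; the gap between them is a 1.4-fold higher number from compound 1 to compound 2 (0.15 log units; within the scatter). Compound 3 `O=C1C=C[C@@H](OCc2ccccc2)[C@@H]([C@@H](CO)OCc2ccccc2)O1` is not yet measured. It differs from compound 2 in one place: hydrogen in place of acetyl on an oxygen on a saturated carbon. Among the compounds with values here, the only measured step that bears on this position is a 1.4-fold higher number from compound 1 to compound 2 (0.15 log units; within the scatter), in which one acyl group replaced another on the carbonyl carbon and the number moved little. Within the data shown here, removing the acyl group altogether is a different kind of change at the same oxygen, and no measured step anchors it, so a shift beyond the scatter in either direction cannot be excluded. The step expected from this change is a 1.2-fold higher number from compound 2 to compound 3 (0.09 log units; within the scatter), toward a somewhat higher number. For compound 3 the estimate in this assay is 18000 nM, with a range from 7000 nM to 45000 nM.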

Compound 3, half-maximal inhibitory concentration: 12300 nM
Beside the measured number, compound 3's estimate is 1.5-fold (0.17 log units) above it; the range from low to high includes it.
By their numbers in this assay, from the lowest: compounds 1, 3 and 2 (each within the scatter of the next).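

In this assay, the change from acetoxy to hydroxy on this saturated carbon gives a 1.2-fold lower number from compound 2 to compound 3 (0.08 log units; within the scatter), and removing the (2-(4-methoxyphenyl)ethenyl)carbonyl group from the same oxygen gives a 1.2-fold higher number from compound 1 to compound 3 (0.08 log units; within the scatter). Going by these compounds alone, the earlier step compared only one acyl group with another, whereas these steps show that the free hydroxy compound cannot be separated from either ester in this assay, so an acyl group on this oxygen is not required for a number in this range. No available evidence accounts for this flat reading.

From the compounds shown here alone, whether an amine or a carboxylic acid at this place would also stay within the scatter remains open. All three compounds carry the same benzyloxy groups and shared core, so they do not show how changes elsewhere would read.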